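A Nitro Group in Place of Chlorine on a Urea

The compounds below may be only part of what the source reports. "The series", "measured", "known", "first", "only" and "open" are said of these compounds alone.

Three ureas share one core: compound 1 `Cc1cc(NC(=O)Nc2ncccc2C)c2ccccc2n1`, compound 2 `Cc1cc(NC(=O)Nc2cccc(Cl)c2)c2ccccc2n1` and compound 3 `Cc1cc(NC(=O)Nc2cc(Cl)cc(Cl)c2)c2ccccc2n1`. Within the data shown here, in an ADME assay on HEK293 cells (Homo sapiens) for cytotoxicity, with a stated time of 72 h (on this read-out lower numbers stand for an effect already at smaller amounts and higher numbers for an effect only at larger amounts of compound), compound 2 gives 21000 nM, the only number among the three. For compound 1 the assay reports only a limit, > 25000 nM. For compound 3 it likewise reports only a limit, > 25000 nM. Two of the three values thus sit at the limit of > 25000 nM in this assay, at which 2 of the 3 values shown sit. The measured steps show an at least 1.1-fold lower number from compound 1 to compound 2 (0.07 log units; that floor lies within the scatter) and an at least 1.1-fold higher number from compound 2 to compound 3 (0.07 log units; that floor lies within the scatter). Compound 4 `Cc1cc(NC(=O)Nc2cccc([N+](=O)[O-])c2)c2ccccc2n1` differs from compound 2 by nitro in place of chloro on an aromatic carbon. Both known steps have floors within the scatter, so in this assay no shift beyond the scatter is expected. Compound 4 is therefore expected near 22000 nM, between 10000 nM and 50000 nM, meaning a 1.0-fold higher number from compound 2 to compound 4 (0.02 log units; within the scatter).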

Compound 4, half-maximal effective concentration: > 25000 nM
Compound 4 gave a limit, no number; the forecaster's own chance of this, stated with the estimate: 55%; middle value at least 1.1-fold (0.05 log units) away from the limit.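

On this aromatic carbon, nitro in place of chloro gives an at least 1.1-fold higher number from compound 2 to compound 4 (0.07 log units; that floor lies within the scatter) in this assay. The earlier steps shown here exchanged the whole aromatic group or added a second chloro, whereas this one replaces the chloro of compound 2 itself, and it too shows no shift beyond the scatter. The true size of the step cannot be read, because compound 4 gives only a limit and joins most of the set there: the limit of > 25000 nM in this assay, at which 3 of the 4 values shown sit.

Still open, as far as these compounds go, is whether an amine or a carboxylic acid on this carbon would give a real number in this assay, and whether that number would differ beyond the scatter from that of compound 2.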